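The source may hold more compounds than are shown below. What is called first, only, known or untested is meant among the compounds shown, and "the series" means these compounds.

Measured compounds:
- compound 1, `Cc1cc(Nc2cc(-c3ccccc3)[nH]n2)n2nc(SCC3CCCCC3)nc2n1`: in a functional assay on PC-9 cells (Homo sapiens) for inhibition, read by MTT assay, with a stated time of 72 h (on this read-out lower numbers stand for stronger inhibition and higher numbers for weaker inhibition), compound 1 gives > 50000 nM, a limit of the assay rather than a number.
- compound 2, `Cc1cc(Nc2cc(-c3ccccc3)[nH]n2)n2nc(SCc3ccc(Cl)cc3)nc2n1`: in this assay compound 2 gives 6710 nM.
- compound 3, `C#CCSc1nc2nc(C)cc(Nc3cc(-c4ccccc4)[nH]n3)n2n1`: in this assay compound 3 gives > 50000 nM, again a limit of the assay.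

Compound 3 therefore stands at the limit, the same one at which compound 1 sits (the limit of > 50000 nM in this assay, at which 2 of the 3 values shown sit); only compound 2 carries a number. Compound 4, `Cc1cc(Nc2cc(-c3ccccc3)[nH]n2)n2nc(SCC3CC3)nc2n1`, differs from compound 3 by cyclopropyl in place of ethynyl on a saturated chain carbon bound to a sulfur.

For the measured compounds named here, two measured steps bear on this position. Going an at least 7.4-fold lower number from compound 1 to compound 2 (0.87 log units; beyond the scatter) is at least modest, and going an at least 7.4-fold higher number from compound 2 to compound 3 (0.87 log units; beyond the scatter) is at least modest in the other direction; the step that the two limits leave unreadable from compound 1 to compound 3 cannot be read, as both ends are limits. Cyclopropyl, like cyclohexyl in compound 1 and ethynyl in compound 3, is not 4-chlorophenyl, and both of those compounds sit at the limit. Compound 4 is therefore expected to stay near or at the limit, with the step of a number no higher from compound 3 to compound 4 (the limit leaves the size open) expected not to be readable. The estimate for compound 4 is 50000 nM, range 15000 nM to 200000 nM.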

Compound 4, half-maximal inhibitory concentration: > 50000 nM
Compound 4 was reported as a limit; the forecaster's own chance of this, stated with the estimate: 60%; the middle value sits exactly at the limit.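

In this assay, for the compounds shown here, going from 4-chlorophenyl to cyclopropyl on the saturated chain carbon bound to a sulfur gives an at least 7.4-fold higher number from compound 2 to compound 4 (0.87 log units; beyond the scatter), so a three-membered carbon ring joins cyclohexyl and ethynyl among the groups that give no number, and 4-chlorophenyl remains the only group here that does. The steps among compound 1, compound 3 and compound 4 cannot be read, as both ends of each are limits, so these three groups cannot be ranked against one another. Compound 2 thus remains the single measured value in the set, with the rest at one limit: the limit of > 50000 nM in this assay, at which 3 of the 4 values shown sit.

Open, on these data alone, is whether a plain phenyl, a 4-methoxyphenyl or a pyridine ring on that chain carbon would also give a number. Also open, as far as these compounds go, is whether the chlorine or the aromatic ring of compound 2 accounts for its gap to compound 4.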